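This account rests on a few compounds, and the source may have more. Where it says the series, first, only, none or still open, it means among the compounds named here.

Measured so far:
compound 1 `COc1ccc(-c2cc3ccccc3nc2C=O)cc1` — > 10000 nM
compound 2 `COc1ccc(-c2cc3ccccc3nc2/C=C/C(=O)c2ccccc2)cc1` — 7410 nM

Two compounds of the series have been run in a functional assay on A549 cells (Homo sapiens) for antiproliferative activity, read by XTT assay, with a stated time of 72 h; a lower number here means a stronger inhibitor, a higher number a weaker inhibitor. For compound 1 the result is a limit of the assay, > 10000 nM, not a number; it sits at the limit of > 10000 nM in this assay, at which 1 of the 2 values shown sits. Among the measured compounds shown here, compound 2 gives 7410 nM in this assay, the only actual number so far, so there is no measured step that would set a scale for what a change on the benzoyl ring does.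

Compound 3 `COc1ccc(-c2cc3ccccc3nc2/C=C/C(=O)c2ccc(F)cc2)cc1` is the next compound to go into this assay. Its difference from compound 2: fluoro in place of hydrogen on an aromatic carbon. For the measured compounds named here, no pair already measured differs in this way, so any expectation rests on compound 2 alone and on the smallness of the change. The step from compound 2 to compound 3 is expected to be small, in either direction, or none beyond the scatter, with the result staying near that of compound 2. Compound 3 is estimated at 5500 nM, with a range from 2200 nM to 13000 nM. This estimate means an expected step of a 1.3-fold lower number from compound 2 to compound 3 (0.13 log units; within the scatter).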

Compound 3, half-maximal inhibitory concentration: 8320 nM
Compound 3: middle estimate off by 1.5-fold (0.18 log units), on the low side, within the range that was stated.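

In this assay, the series now has its first measured step, a 1.1-fold higher number from compound 2 to compound 3 (0.05 log units; within the scatter), and it shows that fluoro in place of hydrogen on this aromatic carbon, para to a large group, does not separate the two compounds beyond the scatter. The position therefore accepts this one-atom exchange, phenyl to 4-fluorophenyl, without a readable step, although a single pair sets no scale for larger exchanges and gives no cause for the outcome. Compound 1 remains a limit of the assay rather than a number, so the step above is the only one that can be read: the limit of > 10000 nM in this assay, at which 1 of the 3 values shown sits.

From the compounds shown here alone, whether an amine, a carboxylic acid or a longer chain such as n-butyl on the same aromatic carbon would give a step beyond the scatter remains open. Also open, going by these compounds, is whether a chloro or methoxy group there would behave as fluoro does, and whether any group at this position can bring the series well clear of the values seen so far.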